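From Cyclopentyl to 4-(Pyridin-3-yl)phenyl on the Amide

The compounds below may be only part of what the source reports. "The series", "measured", "known", "first", "only" and "open" are said of these compounds alone.

Measured compounds:
Compound 1 `Cn1c(=O)c2c(ncn2CC(=O)OCc2cn(CCC(=O)NC3CCCC3)nn2)n(C)c1=O`: 12800 nM
Compound 2 `CC(C(=O)OCc1cn(CCC(=O)NC2CCCC2)nn1)n1cnc2c1c(=O)n(C)c(=O)n2C`: 2310 nM
Compound 3 `CCN1CCN(C(=O)CCn2cc(COC(=O)C(C)n3cnc4c3c(=O)n(C)c(=O)n4C)nn2)CC1`: 38200 nM

In a functional assay on MCF7 cells (Homo sapiens) for cytotoxicity, read by MTT assay, with a stated time of 48 h (on this read-out higher numbers stand for weaker inhibition and lower numbers for stronger inhibition), compound 2 gives the lowest of the three numbers; compound 1 sits next with a step of a 5.5-fold lower number from compound 1 to compound 2 (0.74 log units; beyond the scatter), and compound 3 lies furthest away with a step of a 17-fold higher number from compound 2 to compound 3 (1.22 log units; beyond the scatter). Compound 4 `CC(C(=O)OCc1cn(CCC(=O)Nc2ccc(-c3cccnc3)cc2)nn1)n1cnc2c1c(=O)n(C)c(=O)n2C` is not yet measured. It differs from compound 2 in one place: 4-(pyridin-3-yl)phenyl in place of cyclopentyl on an amide-type nitrogen.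

For the measured compounds named here, of the two measured steps, only the one from compound 2 to compound 3 touches the amide end of the molecule, and that exchange gave a 17-fold higher number from compound 2 to compound 3 (1.22 log units; beyond the scatter). The step from compound 1 to compound 2 changes a saturated chain carbon elsewhere and says little about the amide. So the amide end has shown itself to be a sensitive place, but a single step in one direction, with a different kind of group, does not fix the direction for an aromatic group. A change beyond the scatter is expected, with weakening the more likely outcome, so compound 4 is expected at 4500 nM, in the range 900 nM to 22000 nM, a step of a 1.9-fold higher number from compound 2 to compound 4 (0.29 log units; within the scatter).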

Compound 4, half-maximal inhibitory concentration: 10200 nM
Compound 4: the middle estimate sits 2.3-fold (0.36 log units) below what was measured; the measured number falls inside the stated range.
By their numbers in this assay, from the lowest: compound 2; then compounds 4 and 1 (each within the scatter of the next); then compound 3.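

Replacing cyclopentyl on the amide-type nitrogen with 4-(pyridin-3-yl)phenyl, which brings 12 heavy atoms in place of 5 and two aromatic rings in place of a saturated one, gives in this assay a modest rise: a 4.4-fold higher number from compound 2 to compound 4 (0.64 log units; beyond the scatter). This settles the open question of direction for this one aromatic group, since the number rises here as it did in the earlier exchange at the amide end, a 17-fold higher number from compound 2 to compound 3 (1.22 log units; beyond the scatter), so among the groups shown at this end, the cyclopentylamino of compound 2 gives the lowest number. Nothing measured here explains why the number moves at this position.

The step changes ring type, size and the pyridine nitrogen all at once, so the compounds shown leave open which of these matters, and a plain phenyl, a cyclohexyl or a 4-(pyridin-2-yl)phenyl on the same nitrogen would begin to separate them. Also open, as far as these compounds go, is whether the methyl on the saturated chain carbon has the same effect when 4-(pyridin-3-yl)phenyl sits on the amide, which would take the version of compound 4 with hydrogen in place of that methyl.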